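This account rests on a few compounds, and the source may have more. Where it says the series, first, only, none or still open, it means among the compounds named here.

Of the compounds shown here, two sharing one core have been measured in an assay on isolated protein for inhibition of lysine-specific demethylase 5C (Homo sapiens), read by AlphaScreen, with stated times of 15 min and 20 min; on this read-out higher numbers stand for weaker inhibition and lower numbers for stronger inhibition. Compound 1 `CN1CCN(Cc2nccc3c(=O)[nH]cnc23)CC1` gives 1300 nM, the lower of the two numbers. Compound 2 `CN(C)Cc1nccc2c(=O)[nH]cnc12` gives 8400 nM, a weaker result that lies beyond the usual scatter, so compound 1 stands as the stronger inhibitor of the pair. Compound 3 `O=c1[nH]cnc2c(CN3CCN(c4ccccc4)CC3)nccc12` has not yet been tested in this assay. It differs from compound 1 in one place: phenyl in place of methyl on an amine nitrogen in a ring. For the measured compounds named here, no step of this kind has been measured between tested compounds, so the expectation rests on the two numbers alone. Since compound 2 gives 8400 nM and compound 1 gives 1300 nM, the move to a bulkier amine substituent is expected to bring at most a modest gain, a 1.6-fold lower number from compound 1 to compound 3 (0.21 log units; within the scatter), close to the scatter rather than clearly beyond it. Compound 3 is expected to give 800 nM, with a range from 250 nM to 3000 nM.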

Compound 3, half-maximal inhibitory concentration: > 100000 nM
Compound 3 gave a limit, no number; the forecaster's own chance of this, stated with the estimate: 3%; middle value at least 120-fold (2.09 log units) away from the limit.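

For compound 3, the reading in this assay is a limit of the assay and not a number: the limit of > 100000 nM in this assay, at which 1 of the 3 values shown sits.

Phenyl in place of methyl on the amine nitrogen in the ring brings an at least 76-fold higher number from compound 1 to compound 3 (1.88 log units; beyond the scatter), which is beyond the scatter and large. The earlier compounds shown here offered no step at this position, and this one shows that inhibition here depends strongly on the group carried by that nitrogen, with the methyl of compound 1 retaining measurable inhibition and the phenyl of compound 3 giving only a limit.

The compounds shown leave open whether the loss goes with the phenyl itself or with any group larger than methyl on this nitrogen. An ethyl, a cyclohexyl or a benzyl group there would separate these readings, and a hydrogen in place of methyl would show whether methyl is needed at all.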